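This account rests on a few compounds, and the source may have more. Where it says the series, first, only, none or still open, it means among the compounds named here.

In a functional assay on A549 cells (Homo sapiens) for inhibition (a higher number here means a weaker inhibitor, a lower number a stronger inhibitor), the measured compounds are:

- compound 1 `CCN(C(=O)CC(CC(=O)NCCN1CCCCC1)c1ccc(Cl)cc1)C1Cc2ccccc2C1`: 13200 nM
- compound 2 `CCN(C(=O)CC(CC(=O)NCCN1CCCC1)c1ccc(Cl)cc1)C1Cc2ccccc2C1`: 22600 nM

Among the compounds with values here, compound 2 stands within the scatter of compound 1, the only other measured compound. Compound 3 `CCN(CC)CCNC(=O)CC(CC(=O)N(CC)C1Cc2ccccc2C1)c1ccc(Cl)cc1` differs from compound 2 in one place: diethylamino in place of pyrrolidin-1-yl on a saturated chain carbon, two bonds along the chain from an amide-type nitrogen. Diethylamino stands in place of pyrrolidin-1-yl on a saturated chain carbon, two bonds along the chain from an amide-type nitrogen. Within the data shown here, the only measured step at this place is a 1.7-fold higher number from compound 1 to compound 2 (0.23 log units; within the scatter). With that single step as a guide, no change beyond the scatter is expected in this assay. The expected step is a 1.3-fold lower number from compound 2 to compound 3 (0.10 log units; within the scatter). Compound 3 is estimated at 18000 nM, with a range of 9000 nM to 36000 nM.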

Compound 3, half-maximal inhibitory concentration: 18400 nM
For compound 3 the middle estimate is 1.0-fold (0.01 log units) below the measured one, and the stated range covers the measured number.
By their numbers in this assay, from the lowest: compounds 1, 3 and 2 (each within the scatter of the next).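

The earlier pair changed only the size of the ring on this chain. Compound 3 shows that in this assay the ring itself can be opened, at this place on a saturated chain carbon, two bonds along the chain from an amide-type nitrogen, without a change beyond the scatter: the numbers show a 1.2-fold lower number from compound 2 to compound 3 (0.09 log units; within the scatter) and a 1.4-fold higher number from compound 1 to compound 3 (0.14 log units; within the scatter). No available evidence bears on this result.

All three compounds stand within the scatter of one another, so no group shown here separates from the others. As far as these compounds go, whether morpholin-4-yl, a primary amine or a longer chain to the amine would move the number remains open.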